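A few compounds are considered here, and "the series" means these few. Any claim that something is new, unique, unknown or untested is made for them only; others in the source may bear on it.

Working notes on the series. Compound 1 `[O-]/[N+](=C\c1cn(-c2ccccc2)nn1)c1ccccc1` is measured in a functional assay on PC-3 cells (Homo sapiens) for inhibition, read by MTT assay, with a stated time of 24 h (on this read-out higher numbers stand for weaker inhibition and lower numbers for stronger inhibition), where compound 1 reports only a limit, > 100000 nM. Within the data shown here, compound 2 `[O-]/[N+](=C\c1cn(-c2ccc(F)cc2)nn1)c1ccccc1` carries fluoro in place of hydrogen on an aromatic carbon, and in this assay compound 2 gives 11400 nM, the only number in the set. Among the measured compounds shown here, the step of an at least 8.7-fold lower number from compound 1 to compound 2 (0.94 log units; beyond the scatter) is the sole measured comparison. Compound 3 `[O-]/[N+](=C\c1cn(-c2ccc(Cl)cc2)nn1)c1ccccc1` differs from compound 2 by chloro in place of fluoro on an aromatic carbon. For the measured compounds named here, no measured step covers a swap of one halogen for another, so the measured step gives only a loose guide. For compound 3 a step of a 1.6-fold lower number from compound 2 to compound 3 (0.21 log units; within the scatter) is expected, within the scatter. Compound 3 is estimated at 7000 nM, between 2000 nM and 25000 nM.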

Compound 3, half-maximal inhibitory concentration: 11100 nM
Estimate against measurement, compound 3: 1.6-fold (0.20 log units) below; low and high end bracket the measured number.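

In this assay the swap of one halogen for the other gives a 1.0-fold lower number from compound 2 to compound 3 (0.01 log units; within the scatter), so chloro and fluoro on this aromatic carbon, para to a large group, cannot be told apart. Replacing hydrogen with chloro gives an at least 9.0-fold lower number from compound 1 to compound 3 (0.95 log units; beyond the scatter), which shows that the drop seen with fluoro is not confined to that one halogen. The size of this step stays open-ended, since compound 1 reports only a limit: the limit of > 100000 nM in this assay, at which 1 of the 3 values shown sits.

Still open, going by these compounds, is whether a group other than a halogen, such as methoxy, an amine or a carboxylic acid, would give a similar number at this position.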